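Swapping the fused ring system on the amide arm

A few compounds are considered here, and "the series" means these few. Any claim that something is new, unique, unknown or untested is made for them only; others in the source may bear on it.

Measured so far:
Compound 1 `C[C@@H]1CN(c2sc(C3CC3)nc2-c2nc3ccccc3[nH]2)CCN1C(=O)Cn1cnc2cccnc21`: 994 nM
Compound 2 `CCOc1ncc(-c2nc(C(F)(F)F)sc2N2CCN(C(=O)Cn3ccc4cccnc43)[C@H](C)C2)cn1`: 47 nM

Of the compounds shown here, two have been measured in an assay on blood for inhibition of C-X-C chemokine receptor type 3 (Homo sapiens), with a stated time of 30 min; on this read-out lower numbers stand for stronger inhibition and higher numbers for weaker inhibition. Compound 1 gives 994 nM, while compound 2 gives 47 nM. Of the two numbers, compound 2 stands lowest; its nearest neighbour is compound 1, whose value lies well beyond the usual scatter, so compound 2 is clearly the stronger of the pair on this read-out.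

Compound 3 `CCOc1ncc(-c2nc(C(F)(F)F)sc2N2CCN(C(=O)Cn3nccc3C)[C@H](C)C2)cn1` has not yet been measured. It departs from compound 2 at one point: a group of 6 heavy atoms (4 carbon, 2 nitrogen; one five-membered aromatic ring with 2 hetero atoms) in place of a group of 9 heavy atoms (7 carbon, 2 nitrogen; one five-membered aromatic ring with 1 hetero atom, one six-membered aromatic ring with 1 hetero atom), on a saturated chain carbon bound to a carbonyl carbon. In effect the larger two-ring group on the amide arm gives way to a smaller single-ring group.

For the measured compounds named here, no single-point step between measured compounds exists in these data, so the step from compound 2 to compound 3 has to be judged from the change alone. The removal of part of the substituent is expected to lose some potency rather than gain it, and the estimated step of a 3.4-fold higher number from compound 2 to compound 3 (0.53 log units; beyond the scatter) is expected to exceed the scatter. Compound 3 is therefore expected to give about 160 nM, within a range from 40 nM to 650 nM.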

Compound 3, half-maximal inhibitory concentration: 289 nM
Beside the measured number, compound 3's estimate is 1.8-fold (0.26 log units) below it, within the range that was stated.
By their numbers in this assay, from the lowest: compound 2; then compound 3; then compound 1.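

In this assay, the amide arm now has its first reading at a single place: on a saturated chain carbon bound to a carbonyl carbon, putting 5-methyl-1H-pyrazol-1-yl in place of the two-ring group gives a 6.1-fold higher number from compound 2 to compound 3 (0.79 log units; beyond the scatter). The group carried at this position therefore matters to the read-out, and the smaller single-ring group gives up part of the inhibition seen with the larger two-ring group. The first two compounds differ in more than one place and could not tie a difference to this position alone, and nothing measured here explains the change.

The step replaces the whole group at once, so the compounds shown leave open whether the difference follows the second ring, the number of ring nitrogens or the methyl on the single ring. They also leave open how this position would respond to a phenyl ring, a dimethylamino group or a carboxylic acid on the same chain carbon.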